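Dropping the Trifluoromethyl from the Anilide of Compound 2

The source may hold more compounds than are shown below. What is called first, only, known or untested is meant among the compounds shown, and "the series" means these compounds.

Compound 2, `CN(C)C(=O)c1cc2cnc(Nc3ccc(NC(=O)C4(C(=O)Nc5ccc(Cl)c(C(F)(F)F)c5)CC4)cc3)nc2n1C1CCCC1`, and compound 1, `CN(C)C(=O)c1cc2cnc(Nc3ccc(NC(=O)C4(C(=O)Nc5ccc(F)cc5)CC4)cc3F)nc2n1C1CCCC1`, share a core and differ at the anilide end. In a functional assay on T47D cells (Homo sapiens) for inhibition, read by CCK-8 assay, with a stated time of 72 h, tested at 10 uM (a lower number here means less inhibition of growth, a higher number more inhibition of growth at the concentration tested), compound 2 gives 55.8%, the lower of the two numbers, while compound 1 gives 67.9%, a gap beyond the usual scatter. Compound 3, `CN(C)C(=O)c1cc2cnc(Nc3ccc(NC(=O)C4(C(=O)Nc5ccc(Cl)cc5)CC4)cc3)nc2n1C1CCCC1`, keeps the chloro group but carries hydrogen in place of trifluoromethyl on an aromatic carbon, at a position ortho to a chloro group. Going by the values given here, no measured pair shows this change, so only a small shift, or none beyond the scatter, is expected here. Compound 3 is expected to give 58% in this assay, between 42% and 74%. That estimate means an expected step of a number 2.2 percentage points higher from compound 2 to compound 3 (within the scatter).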

Compound 3, percent growth inhibition at one concentration: 95%
For compound 3 the middle estimate is 37 percentage points below the measured one, outside the stated range (above it).
By their numbers in this assay, from the lowest: compound 2; then compound 1; then compound 3.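

In this assay, going by these compounds alone, going from 4-chloro-3-(trifluoromethyl)phenyl to 4-chlorophenyl gives the only single-place step available, a number 39.2 percentage points higher from compound 2 to compound 3 (beyond the scatter). This aromatic carbon, ortho to a chloro group, is therefore a place where the substituent matters in this pair, with hydrogen giving more growth inhibition than trifluoromethyl. Nothing shown gives a reason for this step. From the compounds shown here alone, it remains open whether a methyl, a nitrile or a methoxy group on that carbon would read closer to compound 2 or to compound 3. Going by these compounds, whether the high value of compound 3 depends on the chloro group also stays open.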